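This account rests on a few compounds, and the source may have more. Where it says the series, first, only, none or still open, it means among the compounds named here.

Compound 1 `COc1cccc([C@@H]2Oc3cc(O)cc(O)c3C(=O)[C@H]2O)c1` with > 100000 nM (a limit)
Compound 2 `O=C1c2c(O)cc(O)cc2O[C@@H](c2cccc(O)c2O)[C@@H]1O` with 13500 nM (a number)

In a physicochemical assay, read by spectrophotometry, with a stated time of 30 min (on this read-out lower numbers stand for an effect already at smaller amounts and higher numbers for an effect only at larger amounts of compound), compound 2 stands at 13500 nM as the only actual number shown. For compound 1 the value > 100000 nM is a limit of this assay and not a number. Compound 3 `O=C1c2c(O)cc(O)cc2O[C@@H](c2cccc(O)c2)[C@@H]1O` differs from compound 2 by hydrogen in place of hydroxy on an aromatic carbon (hydrogen in place of hydroxy on an aromatic carbon, ortho to a hydroxy group). For the measured compounds named here, no measured step shows this change, so only a tentative expectation can be given: a clear rise in this assay beyond the scatter. The expected size is a 5.2-fold higher number from compound 2 to compound 3 (0.71 log units; beyond the scatter) (an upward step). For compound 3 the estimated value is 70000 nM within an expected range of 25000 nM to 150000 nM (a wide span).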

Compound 3, half-maximal effective concentration: > 100000 nM
Compound 3 was reported as a limit; the forecaster's own chance of this, stated with the estimate: 55%; middle value at least 1.4-fold (0.15 log units) away from the limit.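

Hydrogen in place of hydroxy on this aromatic carbon, ortho to a hydroxy group, gives an at least 7.4-fold higher number from compound 2 to compound 3 (0.86 log units; beyond the scatter) in this assay, the first measured sign that this hydroxy matters to the read-out. Compound 3 gives a limit and not a number, so the step fixes only the smallest size of the change: the limit of > 100000 nM in this assay, at which 2 of the 3 values shown sit. The step between compound 1 and compound 3 cannot be read, as both values are limits.

As far as these compounds go, what remains open is how far the number truly rises, and whether an amine or a carboxylic acid on this carbon would keep a readable value.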